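Phenyl for methyl on compound 2: expected dose

This account rests on a few compounds, and the source may have more. Where it says the series, first, only, none or still open, it means among the compounds named here.

Compound 1 `CC1CC/C(=N\Nc2ccccc2F)c2ncc(C(=O)O)c(=O)n21` and compound 2 `Cc1ccc(N/N=C2\CCC(C)n3c2ncc(C(=O)O)c3=O)cc1` share one core and differ only in the aryl group on the amine nitrogen. In a functional assay on the whole organism for inhibition, with Rattus norvegicus as the target (a higher number here means that more compound is needed for the effect, a lower number that less compound is needed), compound 1 gives > 1000 umol/kg, which is a limit of the assay rather than a number. In this assay compound 2 likewise gives > 1000 umol/kg, again a limit. The step that the two limits leave unreadable from compound 1 to compound 2 therefore cannot be read, as both values sit at the limit of > 1000 umol/kg in this assay, at which 2 of the 2 values shown sit. Compound 2 stands at that limit and nowhere else on the numbers shown. Compound 3 `CC1CC/C(=N\Nc2ccc(-c3ccccc3)cc2)c2ncc(C(=O)O)c(=O)n21` arises from compound 2 by phenyl in place of methyl on an aromatic carbon. Among the measured compounds shown here, no measured step bears on this change, and the only measured step is unreadable, so no direction can be taken from it; the sole expectation is that the dose remains near the limit. Compound 3 is estimated at 1500 umol/kg in this assay, with a range from 400 umol/kg to 6000 umol/kg, meaning an expected step that the limit leaves unreadable from compound 2 to compound 3.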

Compound 3, dose for 50% inhibition: > 100 umol/kg
Compound 3 gave a limit, no number; the forecaster's own chance of this, stated with the estimate: 75%; the middle value lies beyond the limit too.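

In this assay compound 3 gives > 100 umol/kg, a limit and not a number. Among the compounds shown here, no step between compound 2 and compound 3 can be read. The compounds shown leave open whether any aryl group on the amine nitrogen changes the dose at all: none of the three has a readable number.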